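Methoxy for Chloro on a Nitrooxyacetamide Chalcone

The source may report more compounds than this note shows. Statements on the series, on what has been measured and on what is new or still open speak of the compounds shown alone.

Measured so far:
compound 1, `COc1ccc(/C=C/C(=O)c2ccc(NC(=O)CBr)cc2)cc1`, gives 34%
compound 2, `O=C(CO[N+](=O)[O-])Nc1ccc(C(=O)/C=C/c2ccc(Cl)cc2)cc1`, gives 60%

Of the compounds shown here, two have been tested in a functional assay on the whole organism (strain albino) for inhibition, with Rattus norvegicus as the target, read by paw edema, with stated times of 30 min and 5 h, at a dose of 100 mg/kg by the oral route; a higher number here means more inhibition at the dose given (going by the name of the read-out), a lower number less inhibition. Compound 2 stands highest of the two numbers; its nearest neighbour, compound 1, lies a number lower that is beyond the scatter. Among the compounds with values here, the two measured compounds differ from one another in more than one place, so no single step between them is computed, and their values show only that compound 2 gave more inhibition than compound 1 at the dose given.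

Compound 3, `COc1ccc(/C=C/C(=O)c2ccc(NC(=O)CO[N+](=O)[O-])cc2)cc1`, has not yet been measured. It differs from compound 2 in one place: methoxy in place of chloro on an aromatic carbon. Within the data shown here, the group that enters is the one that compound 1 carries on the same ring, while the amide end of compound 3 is that of compound 2.

Since no single change is isolated by the measured pair, the step from compound 2 to compound 3 in this assay is expected to be small, in the downward direction and likely within the scatter, so that a number 8 percentage points lower from compound 2 to compound 3 (within the scatter) is estimated. Compound 3 is expected to give 52%, within a range from 36% to 66%.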

Compound 3, a percentage reported as inhibition, in the whole organism at one dose (the size of the read-out at that dose, not a potency): 46%
Estimate against measurement, compound 3: 6 percentage points above, and the stated range covers the measured number.
By their numbers in this assay, from the lowest: compound 1; then compound 3; then compound 2.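

In this assay, replacing 4-chlorophenyl with 4-methoxyphenyl while the nitrooxyacetamide end stays fixed gives a number 14 percentage points lower from compound 2 to compound 3 (beyond the scatter), so the activity of this series responds to the group on this ring carbon, with chloro ahead of methoxy in this one pair. With the 4-methoxyphenyl end held fixed, nitrooxy in place of bromo on the saturated chain carbon bound to the carbonyl carbon gives a number 12 percentage points higher from compound 1 to compound 3 (beyond the scatter), which shows that the chain end also affects the read-out, a point the first two compounds could not separate from the ring change. No measurement available here accounts for either step.

From the compounds shown here alone, each change is seen only once, against a single partner, so it remains open whether the ring step would hold with bromo on the chain, or the chain step with chloro on the ring. Going by these compounds, how an amine or a hydroxyl on the ring carbon, or a longer chain between the amide carbonyl and the nitrooxy group, would compare with these compounds also remains open.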